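The compounds below may be only part of what the source reports. "The series", "measured", "known", "first", "only" and "open" are said of these compounds alone.

Working notes on the series.

Three sulfonamides sharing the core of compound 1 `CCCN(CCC)c1c([N+](=O)[O-])cc(S(=O)(=O)Nc2ccc(OC)cc2)cc1[N+](=O)[O-]` have been measured in a functional assay on J774 cells (Mus musculus) for cytotoxicity; a lower number here means a stronger inhibitor, a higher number a weaker inhibitor. Compound 1 gives 15000 nM, the highest of the three numbers. Compound 2 `CCCN(CCC)c1c([N+](=O)[O-])cc(S(=O)(=O)Nc2ccc(Cl)cc2)cc1[N+](=O)[O-]` gives 10000 nM; the step of a 1.5-fold lower number from compound 1 to compound 2 (0.18 log units; within the scatter) is within the scatter. Compound 3 `CCCN(CCC)c1c([N+](=O)[O-])cc(S(=O)(=O)Nc2ccc(Cl)c(Cl)c2)cc1[N+](=O)[O-]` gives 7200 nM; the step of a 2.1-fold lower number from compound 1 to compound 3 (0.32 log units; beyond the scatter) is beyond the scatter, though modest, while a 1.4-fold lower number from compound 2 to compound 3 (0.14 log units; within the scatter) is within it.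

Compound 4 `CCCN(CCC)c1c([N+](=O)[O-])cc(S(=O)(=O)Nc2cc(Cl)cc(Cl)c2)cc1[N+](=O)[O-]` is not yet measured. Against compound 1 the difference is 3,5-dichlorophenyl in place of 4-methoxyphenyl on a sulfonamide nitrogen. The step that bears most directly on it is a 2.1-fold lower number from compound 1 to compound 3 (0.32 log units; beyond the scatter), where a dichlorophenyl also replaced the 4-methoxyphenyl; the single-chloro steps a 1.5-fold lower number from compound 1 to compound 2 (0.18 log units; within the scatter) and a 1.4-fold lower number from compound 2 to compound 3 (0.14 log units; within the scatter) were each within the scatter, and only their sum reached beyond it. Among the compounds with values here, no measured pair separates the dichlorophenyl that enters in compound 4 from the one present in compound 3, so the two dichlorophenyls are taken as alike. On this basis a modest lowering of the number in this assay is expected, of about the size seen from compound 1 to compound 3, and a step within the scatter cannot be ruled out.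

Compound 4 is therefore estimated at 7500 nM, with a range from 4000 nM to 14000 nM, an expected step of a 2.0-fold lower number from compound 1 to compound 4 (0.30 log units; within the scatter).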

Compound 4, half-maximal inhibitory concentration: 5100 nM
Beside the measured number, compound 4's estimate is 1.5-fold (0.17 log units) above it, and the stated range covers the measured number.
By their numbers in this assay, from the lowest: compounds 4, 3, 2 and 1 (each within the scatter of the next, the first and the last beyond it).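

In this assay the 3,5-dichlorophenyl on the sulfonamide nitrogen gives a 2.9-fold lower number from compound 1 to compound 4 (0.47 log units; beyond the scatter) and so remains a modest change, which shows that the 3,4-dichlorophenyl of compound 3 is not the only dichlorophenyl to move the number beyond the scatter from the 4-methoxyphenyl of compound 1. Within the data shown here, the arrangement of the two chloro groups is not resolved here, with a 1.4-fold lower number from compound 3 to compound 4 (0.15 log units; within the scatter) as the only direct comparison of the two dichlorophenyls, and with a 2.0-fold lower number from compound 2 to compound 4 (0.29 log units; within the scatter) the 3,5-dichlorophenyl is not separated from the 4-chlorophenyl either. No evidence is at hand to explain these numbers.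

Going by these compounds, all four compounds carry only methoxy or chloro groups on this aromatic ring, so it stays open how the number would respond to a carboxylic acid or an amine there, or to a phenyl with no substituent at all. The dipropylamino group also stays constant throughout, which leaves open whether a longer chain on that nitrogen would shift the number in this assay by more than the changes seen at the sulfonamide nitrogen.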